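Swapping a trifluoromethyl for a methoxy on the pendant ring

The source may report more compounds than this note shows. Statements on the series, on what has been measured and on what is new or still open speak of the compounds shown alone.

Of the compounds shown here, three sharing one core have been tested in an ADME assay on isolated protein for inhibition of Amine oxidase [flavin-containing] B (Homo sapiens); on this read-out lower numbers stand for stronger inhibition and higher numbers for weaker inhibition. Compound 1, `C#CCNC1CCc2c(SCc3cccc(F)c3)cccc21`, gives 11600 nM. Compound 3, `C#CCNC1CCc2c(SCc3cccc(C(F)(F)F)c3)cccc21`, gives 7710 nM. Compound 2, `C#CCNC1CCc2c(SCc3cccc(Br)c3)cccc21`, reaches only > 100000 nM, which is a limit of this assay rather than a number, as stated in the limit of > 100000 nM in this assay, at which 1 of the 3 values shown sits. Among the two numbers, compound 3 holds the lowest, though its gap to compound 1, a 1.5-fold lower number from compound 1 to compound 3 (0.18 log units; within the scatter), is within the scatter. The other steps are larger: an at least 8.6-fold higher number from compound 1 to compound 2 (0.93 log units; beyond the scatter) and an at least 12-fold lower number from compound 2 to compound 3 (1.11 log units; beyond the scatter).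

Compound 4, `C#CCNC1CCc2c(SCc3cccc(OC)c3)cccc21`, differs from compound 3 by methoxy in place of trifluoromethyl on an aromatic carbon. Among the measured compounds shown here, no measured step involves a methoxy, so none bears on it directly; the three steps only show that exchanging one small group on this ring can leave this assay unchanged or weaken inhibition considerably. A modest weakening is therefore expected, amounting to a 1.9-fold higher number from compound 3 to compound 4 (0.29 log units; within the scatter). Compound 4 is estimated at 15000 nM, with a range from 5000 nM to 60000 nM.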

Compound 4, half-maximal inhibitory concentration: 1520 nM
Beside the measured number, compound 4's estimate is 9.9-fold (0.99 log units) above it, outside the stated range (below it).
By their numbers in this assay, from the lowest: compound 4; then compounds 3 and 1 (each within the scatter of the next). At a limit, above all of these: compound 2.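

In this assay methoxy on this aromatic carbon brings a clear gain, with a 5.1-fold lower number from compound 3 to compound 4 (0.71 log units; beyond the scatter) and a 7.6-fold lower number from compound 1 to compound 4 (0.88 log units; beyond the scatter) even though fluoro and trifluoromethyl could not be told apart here. Among the compounds shown here, compound 4 is the only compound whose steps to all the others lie beyond the scatter, which makes it the strongest inhibitor of the four and shows that this position can improve inhibition as well as weaken it. The change from bromo appears as an at least 65-fold lower number from compound 2 to compound 4 (1.81 log units; beyond the scatter) but compound 2 gives a limit and not a number: the limit of > 100000 nM in this assay, at which 1 of the 4 values shown sits.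

The compounds shown cannot say whether the gain belongs to the oxygen of methoxy or to the group as a whole. A hydroxy, an ethoxy or a plain methyl on this carbon would help separate the two.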